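The source may report more compounds than this note shows. Statements on the series, on what has been measured and on what is new or still open speak of the compounds shown alone.

In a functional assay on KB cells (Homo sapiens) for inhibition, read by sulforhodamine B assay, with a stated time of 72 h (a higher number here means a weaker inhibitor of growth, a lower number a stronger inhibitor of growth), compound 3 (`CNC(=O)CCc1ccncc1-c1ccc2ccccc2c1`) gives only a limit, > 10000 nM. Compound 1 (`NNC(=O)CCc1ccncc1-c1ccc2ccccc2c1`) also gives only a limit, > 10000 nM. Compound 2 (`CCOC(=O)/C=C/c1ccncc1-c1ccc2ccccc2c1`) likewise gives only a limit, > 10000 nM. The whole picture so far is the limit of > 10000 nM in this assay, at which 3 of the 3 values shown sit, so no measured number yet shows any of these compounds stopping growth.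

The next structure is compound 4 (`NC(=O)/C=C/c1ccncc1-c1ccc2ccccc2c1`), which has 2-carbamoylethenyl in place of 2-(methylcarbamoyl)ethyl on an aromatic carbon.

Within the data shown here, three measured steps bear on this change: a step that the two limits leave unreadable from compound 1 to compound 2, a step that the two limits leave unreadable from compound 1 to compound 3 and a step that the two limits leave unreadable from compound 2 to compound 3. None of them has a readable size, although together they cover changes to the amide nitrogen and to the chain. They give no sign that either kind of change moves this assay, so no step beyond the usual scatter is expected, though the limits cannot exclude one.

The expected change is a step that the limit leaves unreadable from compound 3 to compound 4. For compound 4 the estimated value is 12000 nM, with an expected range from 4000 nM to 30000 nM.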

Compound 4, concentration for 50% growth inhibition: > 10000 nM
Compound 4: only a limit was reported; the forecaster's own chance of this, stated with the estimate: 80%; the middle value is on the limit's open side.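

In this assay compound 4 gives > 10000 nM, which is only a limit. Its steps from compound 1, compound 2 and compound 3 therefore cannot be read: the limit of > 10000 nM in this assay, at which 4 of the 4 values shown sit.

The compounds shown leave open whether any change to this chain on the shared core affects growth inhibition, and by how much.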